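Moving the chlorine on compound 2

A few compounds are considered here, and "the series" means these few. Any claim that something is new, unique, unknown or untested is made for them only; others in the source may bear on it.

Going by the values given here, in a functional assay on A549 cells (Homo sapiens) for inhibition, read by MTT assay, with a stated time of 48 h (a lower number here means a stronger inhibitor, a higher number a weaker inhibitor), compound 2 `COc1ccc2c(=O)c(/C=C/C(=O)Nc3cccc(Cl)c3)coc2c1` gives 470 nM, the only true number among the measured compounds. Compound 1 `COc1ccc2c(=O)c(/C=C/C(=O)Nc3cccc(C)c3)coc2c1` gives > 100000 nM, which is a limit of the assay and not a number. Compound 3 `COc1ccc(CNC(=O)/C=C/c2coc3cc(O)ccc3c2=O)cc1` gives > 100000 nM, which is also a limit.

Compound 4 `COc1ccc2c(=O)c(/C=C/C(=O)Nc3ccccc3Cl)coc2c1` has not yet been measured. It differs from compound 2 as follows: 2-chlorophenyl in place of 3-chlorophenyl on an amide-type nitrogen. The chlorine therefore stays in the molecule and only its place changes.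

Among the compounds with values here, the one measured step that bears on this is an at least 210-fold lower number from compound 1 to compound 2 (2.32 log units; beyond the scatter), with chloro in place of methyl on an aromatic carbon. That step swapped one group for another rather than moving a group, so it is only indirect guidance. Still, it shows that a small edit to this part of the molecule can have a large effect in this assay.

A weaker result beyond the scatter, but smaller than that step, is expected. The range stays wide because of the limit of > 100000 nM in this assay, at which 2 of the 3 values shown sit. The expected change is a 5.3-fold higher number from compound 2 to compound 4 (0.73 log units; beyond the scatter). For compound 4, the estimated value is 2500 nM, with an expected range of 250 nM to 50000 nM.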

Compound 4, half-maximal inhibitory concentration: 29900 nM
Compound 4: the middle estimate sits 12-fold (1.08 log units) below what was measured; low and high end bracket the measured number.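

Until now, only a swap of one group for another had been seen at this part of the molecule. Here the atoms stay the same and only their joining changes, yet the result moves strongly, with a 64-fold higher number from compound 2 to compound 4 (1.80 log units; beyond the scatter), so the presence of a chlorine alone does not give the low number of compound 2. The other new step, an at least 3.3-fold lower number from compound 1 to compound 4 (0.52 log units; beyond the scatter), rests on a limit for compound 1 and so gives only a minimum: the limit of > 100000 nM in this assay, at which 2 of the 4 values shown sit.

From the compounds shown here alone, it remains open whether the low number of compound 2 would hold with another group in the place of the chlorine on the 3-chlorophenyl, such as bromo, a nitrile or a trifluoromethyl. Going by these compounds, it is equally open what an amine or a carboxylic acid on that ring would give.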